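The source may hold more compounds than are shown below. What is called first, only, known or untested is meant among the compounds shown, and "the series" means these compounds.

Compound 3, whose structure is `CN1CCC[C@H]1COc1cncc(C(F)(F)F)c1`, stands second highest among the three numbers gathered so far in an assay on membranes from brain for displacement of a labelled ligand from Neuronal acetylcholine receptor; alpha4/beta2 (Rattus norvegicus) (on this read-out higher numbers stand for weaker inhibition and lower numbers for stronger inhibition), where compound 3 gives 1.83 nM. Its nearest neighbour is compound 1, with the structure `CN1CCC[C@H]1COc1cccnc1`, which in this assay gives 0.15 nM; furthest away is compound 2, with the structure `CCN(CC)C(=O)c1ccncc1OC[C@@H]1CCCN1C`, which in this assay gives 2830 nM. The step from compound 3 to compound 4, whose structure is `CC(=O)c1cncc(OC[C@@H]2CCCN2C)c1`, is acetyl in place of trifluoromethyl on an aromatic carbon. For the measured compounds named here, two measured steps bear on it. The step of a 12-fold higher number from compound 1 to compound 3 (1.09 log units; beyond the scatter) shows that the trifluoromethyl that now leaves had itself raised the number from the unsubstituted core. The step of a 19000-fold higher number from compound 1 to compound 2 (4.28 log units; beyond the scatter) shows that a carbonyl-bearing group entering on another aromatic carbon of the same core raised the number far more, though that group is larger and sits elsewhere. Since compound 4 keeps the place of the substituent of compound 3 and exchanges one small group for another that carries a carbonyl, a modest rise beyond the scatter is expected, smaller than a 19000-fold higher number from compound 1 to compound 2 (4.28 log units; beyond the scatter). Compound 4 is therefore estimated at 5 nM in this assay, within 0.8 nM to 30 nM, a step of a 2.7-fold higher number from compound 3 to compound 4 (0.44 log units; beyond the scatter).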

Compound 4, inhibition constant: 1.19 nM
Compound 4: the middle estimate sits 4.2-fold (0.62 log units) above what was measured; the measured number falls inside the stated range.
By their numbers in this assay, from the lowest: compound 1; then compounds 4 and 3 (each within the scatter of the next); then compound 2.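

In this assay, compound 3 and compound 4 cannot be told apart, a 1.5-fold lower number from compound 3 to compound 4 (0.19 log units; within the scatter), even though acetyl brings a hydrogen-bond acceptor and a double bond that trifluoromethyl does not have. For the compounds shown here, until now, only one group had been seen at this place; with a 7.9-fold higher number from compound 1 to compound 4 (0.90 log units; beyond the scatter) alongside a 12-fold higher number from compound 1 to compound 3 (1.09 log units; beyond the scatter), two different groups at this place are each seen to raise the number beyond the scatter from that of the unsubstituted core, and neither can be ranked above the other. No measurement at hand explains this result.

Going by these compounds, it remains open whether a small group of another kind at this place, such as an amine, a hydroxyl or a carboxylic acid, or a longer chain such as propanoyl, would stay close to compound 3 and compound 4 or would return towards compound 1. On these data alone, it also remains open whether a 19000-fold higher number from compound 1 to compound 2 (4.28 log units; beyond the scatter) belongs to the diethylcarbamoyl group itself or to the aromatic carbon it occupies, a question that a diethylcarbamoyl at the place of the acetyl would answer.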